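The source may report more compounds than this note shows. Statements on the series, on what has been measured and on what is new or still open speak of the compounds shown alone.

Compounds measured so far:

Compound 1, `COC(=O)C1=C(C)N=C(C)/C(=C(\O)OC)C1c1ccc(F)cc1` — 129 nM
Compound 2, `COC(=O)C1=C(C)N=C(C)/C(=C(\O)OC)C1c1cccc(N(C)C)c1` — 891 nM
Compound 3, `COC(=O)C1=C(C)N=C(C)/C(=C(\O)OC)C1c1ccc(C#N)cc1` — 3470 nM

All three share one core and differ only in the group carried on the pendant six-membered aromatic ring. In a functional assay (muscle tissue) with Cavia porcellus as the target (on this read-out lower numbers stand for an effect already at smaller amounts and higher numbers for an effect only at larger amounts of compound), compound 2 stands second highest of the three numbers; compound 3 lies nearest to it, and compound 1 lies furthest, with both gaps beyond the scatter. Going by the values given here, the one measured step between compounds that differ in a single place is the move a 27-fold higher number from compound 1 to compound 3 (1.43 log units; beyond the scatter), which shows that exchanging one small group for another on that ring can shift this assay a long way.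

Compound 4, `COC(=O)C1=C(C)N=C(C)/C(=C(\O)OC)C1c1cccc(C(F)(F)F)c1`, is the next compound to be measured. Relative to compound 2 it carries trifluoromethyl in place of dimethylamino on an aromatic carbon. Among the compounds with values here, no measured step swaps these two groups, so the only guide is the size of the change seen from compound 1 to compound 3 and the spread among the three values. On that basis a step of moderate size is expected, toward a lower number, and the estimate for compound 4 is 200 nM, within 40 nM to 1000 nM, meaning an expected step of a 4.5-fold lower number from compound 2 to compound 4 (0.65 log units; beyond the scatter).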

Compound 4, half-maximal effective concentration: 74.1 nM
For compound 4 the middle estimate is 2.7-fold (0.43 log units) above the measured one; measured number inside the range.
By their numbers in this assay, from the lowest: compounds 4 and 1 (each within the scatter of the next); then compound 2; then compound 3.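

In this assay, the exchange of dimethylamino for trifluoromethyl on an aromatic carbon meta to a large group gives a 12-fold lower number from compound 2 to compound 4 (1.08 log units; beyond the scatter), so one group at this place can shift the read-out a long way, which the earlier step between fluoro and cyano, a 27-fold higher number from compound 1 to compound 3 (1.43 log units; beyond the scatter), had not shown for this place. This step runs toward a lower number, and the exchange removes the hydrogen-bond acceptor counted for dimethylamino while adding none, though one pair of compounds cannot tie the step to that count. No measurement of any property of these groups is available to account for the step.

With only dimethylamino and trifluoromethyl at this place, the compounds shown leave open how a methyl, a chlorine or a primary amine there would read, and so whether losing the nitrogen or gaining the fluorines carries the step. They also leave open what trifluoromethyl would give on the carbon that carries fluoro in compound 1.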